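Swapping a Piperidinyl Carrier for an Anilide on the Core

A few compounds are considered here, and "the series" means these few. Any claim that something is new, unique, unknown or untested is made for them only; others in the source may bear on it.

Measured compounds:
compound 1, `CN1CCN(c2ccc(Nc3ncc4nc(Nc5ccc(F)cc5)n([C@H]5CCN(C(=O)OC(C)(C)C)C5)c4n3)cc2)CC1`: "not determined" (no result reported)
compound 2, `CN1CCN(c2ccc(Nc3ncc4nc(Nc5ccc(F)cc5)n([C@H]5CCCN(C(=O)CO)C5)c4n3)cc2)CC1`: 830 nM

Only compound 2 carries a number. Within the data shown here, in a functional assay on A549 cells (Homo sapiens) for antiproliferative activity, read by MTT assay, with a stated time of 72 h (on this read-out lower numbers stand for stronger inhibition and higher numbers for weaker inhibition), compound 2 gives 830 nM, and compound 1 has no single value, so compound 2 stands alone and no step between measured compounds can be read off. Compound 3, `CN1CCN(c2ccc(Nc3ncc4nc(Nc5ccc(F)cc5)n(-c5cccc(NC(=O)CO)c5)c4n3)cc2)CC1`, is the untested member. Its change against compound 2 is 3-(((hydroxymethyl)carbonyl)amino)phenyl in place of 1-((hydroxymethyl)carbonyl)piperidin-3-yl on an aromatic nitrogen, the shared core and the remaining substituents being kept.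

Among the measured compounds shown here, with no step to lean on, the expectation rests on compound 2 alone. Compound 3 is expected to sit close to compound 2, with any step from compound 2 to compound 3 in this assay estimated as small, a 1.4-fold lower number from compound 2 to compound 3 (0.14 log units; within the scatter), and not clearly beyond the scatter. For compound 3 the estimated value in this assay is 600 nM, within a range of 150 nM to 2500 nM.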

Compound 3, half-maximal inhibitory concentration: 1510 nM
Compound 3: middle estimate off by 2.5-fold (0.40 log units), on the low side; measured number inside the range.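

In this assay, among these compounds, the first step that can be read at this position is a 1.8-fold higher number from compound 2 to compound 3 (0.26 log units; within the scatter). On this read-out, the 1-((hydroxymethyl)carbonyl)piperidin-3-yl and 3-(((hydroxymethyl)carbonyl)amino)phenyl groups cannot be told apart, even though the exchange puts a six-membered aromatic ring of carbon only in place of a non-aromatic ring with one hetero atom, removes the defined stereocentre and brings the count of hydrogen-bond donors to two. No measurement offered here explains the result.

From the compounds shown here alone, it remains open whether a plain phenyl, or a phenyl carrying an amine or a carboxylic acid in place of the hydroxyacetyl amide, would also fall within the scatter of compound 3. The opposite stereoisomer of the piperidin-3-yl group in compound 2 also remains an open case.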